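Swapping Sulfamoyl for Trifluoromethyl: Expected Liver Microsome Stability

The source may report more compounds than this note shows. Statements on the series, on what has been measured and on what is new or still open speak of the compounds shown alone.

Of the compounds shown here, three sharing one core have been tested in an in vitro ADME assay on microsomes from liver (Homo sapiens) for metabolic stability; on this read-out higher numbers stand for a longer-lived compound and lower numbers for a shorter-lived compound. Compound 2 (`COc1ccc(-c2cc(-c3ccc(S(N)(=O)=O)cc3)cnc2N)cn1`) reaches only a limit of this assay, reported as > 4.16 h. Compound 3 (`COc1ccc(-c2cc(-c3ccc(S(C)(=O)=O)c(F)c3)cnc2N)cn1`) likewise reaches only a limit, reported as > 4.16 h. Compound 1 (`COc1ccc(-c2cc(-c3cccc(S(C)(=O)=O)c3)cnc2N)cn1`) gives a number, 3.78 h. Two of the three results therefore sit at the limit of > 4.16 h in this assay, at which 2 of the 3 values shown sit, so compound 2 can be placed only at the top of what this assay shows. Compound 4 (`COc1ccc(-c2cc(-c3ccc(C(F)(F)F)cc3)cnc2N)cn1`) differs from compound 2 by one change: trifluoromethyl in place of sulfamoyl on an aromatic carbon. Within the data shown here, with no measured step of this kind to lean on, the expected step of an at least 1.1-fold lower number from compound 2 to compound 4 (0.07 log units; that floor lies within the scatter) is none beyond the usual scatter. Compound 4 is therefore estimated at 3.5 h, within 1.5 h to 4.16 h.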

Compound 4, half-life: 4.75 h
Compound 4: middle estimate off by 1.4-fold (0.13 log units), on the low side; the whole stated range lies below it.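

No step from compound 2 to compound 4 can be read in this assay, since compound 2 gives only a limit: the limit of > 4.16 h in this assay, at which 2 of the 4 values shown sit.

As far as these compounds go, whether trifluoromethyl in place of sulfamoyl on an aromatic carbon lengthens or shortens the half-life, and by how much, stays open.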